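The source may report more compounds than this note shows. Statements on the series, on what has been measured and on what is new or still open speak of the compounds shown alone.

In a functional assay on A549 cells (Homo sapiens) for cytotoxicity, read by MTT assay, with a stated time of 48 h (a lower number here means a stronger inhibitor, a higher number a weaker inhibitor), compound 2 (`COc1ccc2nc(Cl)c(Cn3cc(CN4c5ccccc5C(C)=CC4(C)C)nn3)cc2c1`) gives 33400 nM and stands within the scatter of both compounds it can be compared with: compound 1 (`COc1ccc2c(c1)C(C)=CC(C)(C)N2Cc1cn(Cc2cc3cc(OC)ccc3nc2Cl)nn1`) gives 30900 nM and compound 3 (`CC1=CC(C)(C)N(Cc2cn(Cc3cc4ccccc4nc3Cl)nn2)c2ccccc21`) gives 17500 nM in the same test. On these numbers, compound 2 is not separated from either of them.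

Compound 4 (`COc1ccc2nc(Cl)c(Cn3cc(CN4c5ccc(C)cc5C(C)=CC4(C)C)nn3)cc2c1`) differs from compound 2 by a single change (methyl in place of hydrogen on an aromatic carbon), methyl in place of hydrogen on an aromatic carbon. No methyl step has been measured among these compounds, so the nearest evidence comes from two methoxy steps. Compound 1 carries a methoxy on the same carbon that bears the new methyl in compound 4, and replacing that methoxy with hydrogen gave a 1.1-fold higher number from compound 1 to compound 2 (0.03 log units; within the scatter) as the closest guide. Replacing the other methoxy with hydrogen gave a 1.9-fold lower number from compound 2 to compound 3 (0.28 log units; within the scatter) as a second, less direct guide. Neither step left the scatter, so the methyl is expected to bring no step beyond the scatter in this assay and no particular direction can be expected.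

The estimate amounts to a 1.1-fold lower number from compound 2 to compound 4 (0.05 log units; within the scatter) as the expected step. For compound 4 the estimated value is 30000 nM with an expected range from 15000 nM to 60000 nM in this test.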

Compound 4, half-maximal inhibitory concentration: 15500 nM
For compound 4 the middle estimate is 1.9-fold (0.29 log units) above the measured one; the measured number falls inside the stated range.
By their numbers in this assay, from the lowest: compounds 4, 3, 1 and 2 (each within the scatter of the next, the first and the last beyond it).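

This carbon, on the six-membered aromatic ring of carbon only, para to a fused ring and meta to a fused ring, looked unresponsive until now, as swapping its methoxy for hydrogen stayed within the scatter (a 1.1-fold higher number from compound 1 to compound 2 (0.03 log units; within the scatter)). In this assay the methyl gives the first step among these compounds to pass beyond the scatter (a 2.2-fold lower number from compound 2 to compound 4 (0.33 log units; beyond the scatter)), so a single added carbon at this position can move the number, though only modestly and only just past the limit of what repeat measurements would separate. Against the methoxy the same methyl stays within the scatter (a 2.0-fold lower number from compound 1 to compound 4 (0.30 log units; within the scatter)), which means the position separates methyl from hydrogen but not methyl from methoxy, and even this rests on one pair of compounds in one cell test.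

Going by these compounds, it remains open whether a longer chain such as ethyl, a chlorine atom, an amine or a carboxylic acid on this carbon would take the number further in either direction, and whether the methyl gives a similar step on the core of compound 3. Nothing in the material shown offers an explanation for the step from hydrogen to methyl.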